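The source may hold more compounds than are shown below. What is called first, only, known or untested is meant among the compounds shown, and "the series" means these compounds.

In a functional assay on MCF7 cells (Homo sapiens) for cytotoxicity, read by MTT assay (on this read-out lower numbers stand for stronger inhibition and higher numbers for weaker inhibition), compound 1 `COc1ccc(-c2oc3c(CC=C(C)C)c(OC(C)C(=O)O)cc(O)c3c(=O)c2O)cc1` reads > 100000 nM as a limit and not a number. Compound 3 `COc1ccc(-c2oc3c(CC=C(C)C)c(OC(C)C(=O)O)cc(O)c3c(=O)c2OC(C)C(=O)O)cc1` reads > 100000 nM; > 100000 nM (2 entries) and that too is a limit. Among the measured compounds shown here, compound 2 `COc1ccc(-c2oc3c(CC=C(C)C)c(OCCOC(=O)CCCC(=O)O)cc(O)c3c(=O)c2OCCOC(=O)CCCC(=O)O)cc1` gives 3000 nM as the only single number so far. Compound 4 `CCOC(=O)COc1cc(O)c2c(=O)c(O)c(-c3ccc(OC)cc3)oc2c1CC=C(C)C` carries (ethoxycarbonyl)methyl in place of 1-carboxyethyl on an oxygen on an aromatic ring on an oxygen on an aromatic ring. For the measured compounds named here, no measured step bears directly on this change. Of the three measured compounds, only compound 2 at 3000 nM lacks 1-carboxyethyl and gives a number, so stronger inhibition is expected for this swap in this assay despite the thin evidence. The expected step of an at least 3.3-fold lower number from compound 1 to compound 4 (0.52 log units; beyond the scatter) is sizeable but loosely fixed, and a reading at the limit remains possible. Compound 4 is estimated at 30000 nM with an expected range of 8000 nM to 100000 nM for this reading.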

Compound 4, half-maximal inhibitory concentration: 27900 nM
Estimate against measurement, compound 4: 1.1-fold (0.03 log units) above; low and high end bracket the measured number.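

In this assay, (ethoxycarbonyl)methyl in place of 1-carboxyethyl on an oxygen on an aromatic ring gives an at least 3.5-fold lower number from compound 1 to compound 4 (0.55 log units; beyond the scatter). This position can therefore yield a readable number with the rest of the core of compound 1 unchanged, and with a single substituted oxygen, unlike the doubly substituted compound 2. The size of the step remains a bound and not a number: the limit of > 100000 nM in this assay, at which 1 of the 4 values shown sits.

Still open, going by these compounds, is whether the ethyl ester or the loss of the methyl branch carries the step, which a carboxymethyl or 1-(ethoxycarbonyl)ethyl group on that oxygen would separate. On these data alone, how an amide or a longer ester chain would read there also remains open.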